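A Smaller Ring on the Thiocarbonyl Carbon of Compound 1

A few compounds are considered here, and "the series" means these few. Any claim that something is new, unique, unknown or untested is made for them only; others in the source may bear on it.

Compound 1, `CC1CCCCN1C(=S)SCc1ccc(C(=O)Nc2ccccc2N)cc1`, was tested in a functional assay on HeLa cells (Homo sapiens) for antiproliferative activity, read by CCK-8 assay, with a stated time of 72 h, tested at 2 uM (a lower number here means a weaker effect, a higher number a stronger effect of the compound at the concentration tested), and gave 45.5%. Going by the values given here, of the two compounds measured so far it stands lowest. Its only companion, compound 2, `Nc1ccccc1NC(=O)c1ccc(CSC(=S)N2CCN(Cc3cccnc3)CC2)cc1`, gave 69.7% in this assay, a number higher than that of compound 1 by a margin beyond the usual scatter; the two structures differ in more than one place, so no single step can be read from that pair.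

The next compound, compound 3, `Nc1ccccc1NC(=O)c1ccc(CSC(=S)N2CCCC2)cc1`, differs from compound 1 in one place: pyrrolidin-1-yl in place of 2-methylpiperidin-1-yl on a thiocarbonyl carbon. The change is confined to the ring attached to the thiocarbonyl carbon, and nothing measured yet shows how this assay responds to such a ring swap on the shared core.

Among the compounds with values here, with no comparable step available, the author expects the change from compound 1 to compound 3 to be small, likely within the scatter, and estimates the step as a number 2.5 percentage points higher from compound 1 to compound 3 (within the scatter). Compound 3 is therefore expected to give about 48% in this assay, within a range from 30% to 66%.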

Compound 3, a percentage reported as inhibition, at one concentration (the size of the read-out at that concentration, not a potency): 51.3%
For compound 3 the middle estimate is 3.3 percentage points below the measured one; the range from low to high includes it.
By their numbers in this assay, from the lowest: compounds 1 and 3 (each within the scatter of the next); then compound 2.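

In this assay, going by these compounds alone, the exchange of 2-methylpiperidin-1-yl for pyrrolidin-1-yl on a thiocarbonyl carbon gives the first reading at this position, a step of a number 5.8 percentage points higher from compound 1 to compound 3 (within the scatter). At the single concentration tested, this read-out therefore does not separate the six-membered non-aromatic ring from the five-membered one, although the two rings differ in size and only the ring that leaves carries a methyl group. No supporting measurement on record explains this outcome or links it to any property of either ring.

The compounds shown leave open how this position would respond to a group of another kind, such as morpholin-4-yl, with an oxygen in the ring, or an open-chain dimethylamino group on the same thiocarbonyl carbon. They also leave open whether compound 1 and compound 3 would remain indistinguishable at other concentrations, since a percentage at one concentration reports the size of the effect there and is not a potency.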